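Swapping one trihalophenyl for another on the sulfonamide nitrogen

A few compounds are considered here, and "the series" means these few. Any claim that something is new, unique, unknown or untested is made for them only; others in the source may bear on it.

Three compounds with a shared core carrying a piperazine and a methoxy group have been measured in an assay on isolated protein for binding affinity to 5-hydroxytryptamine receptor 6 (Homo sapiens); a higher number here means a weaker inhibitor, a lower number a stronger inhibitor. Compound 1 `COc1ccc(S(=O)(=O)Nc2ccc(C)cc2Br)cc1N1CCNCC1` gives 7.94 nM in this assay. Compound 2 `COc1cc(Cl)c(C)cc1NS(=O)(=O)c1ccc(OC)c(N2CCNCC2)c1` gives 2 nM. Compound 3 `COc1ccc(S(=O)(=O)Nc2cc(Cl)c(Cl)cc2Cl)cc1N1CCNCC1` gives 5.01 nM, which places it second highest of the three numbers: its nearest neighbour is compound 1, and the step of a 1.6-fold lower number from compound 1 to compound 3 (0.20 log units; within the scatter) is within the scatter, while compound 2 lies furthest from it, a gap beyond the scatter.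

Compound 4 `COc1ccc(S(=O)(=O)Nc2cc(Br)cc(F)c2Cl)cc1N1CCNCC1` has not yet been measured in this assay. It differs from compound 3 in one place: 5-bromo-2-chloro-3-fluorophenyl in place of 2,4,5-trichlorophenyl on a sulfonamide nitrogen. Among the compounds with values here, the only measured step touching the same position is a 1.6-fold lower number from compound 1 to compound 3 (0.20 log units; within the scatter), in which one substituted phenyl on the sulfonamide nitrogen replaced another without moving the number beyond the scatter. Within the data shown here, no measured pair shows the effect of a bromine, chlorine and fluorine set in this arrangement. On that basis the step of a 1.0-fold lower number from compound 3 to compound 4 (0.00 log units; within the scatter) is expected to stay within the scatter, with no clear direction. Compound 4 is therefore estimated at 5 nM in this assay, with a range from 1.6 nM to 16 nM.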

Compound 4, inhibition constant: 3.16 nM
Compound 4: the middle estimate sits 1.6-fold (0.20 log units) above what was measured; measured number inside the range.
By their numbers in this assay, from the lowest: compounds 2, 4, 3 and 1 (each within the scatter of the next, the first and the last beyond it).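

In this assay, setting 5-bromo-2-chloro-3-fluorophenyl in place of 2,4,5-trichlorophenyl on the sulfonamide nitrogen gives a 1.6-fold lower number from compound 3 to compound 4 (0.20 log units; within the scatter), so a ring carrying bromine, chlorine and fluorine sits within the scatter of the trichlorinated one. The same group in place of 2-bromo-4-methylphenyl gives a 2.5-fold lower number from compound 1 to compound 4 (0.40 log units; beyond the scatter), a modest step but the first at this position that is printed as beyond the scatter. Compound 3 stands within the scatter of both compound 1 and compound 4, so this position shows a difference only between the two ends of that series, and neither step through compound 3 shows one alone.

No measurement at hand bears on why the numbers fall as they do. The compounds shown also leave open how much each halogen of compound 4 contributes on its own, and whether an amine, a carboxylic acid or a longer chain on this phenyl ring would keep the number in the same range.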